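Chain length between iodoacetamide and adenine in hexokinase-3 inhibition

This account rests on a few compounds, and the source may have more. Where it says the series, first, only, none or still open, it means among the compounds named here.

Compound 1 `O=C(CI)NCCCCCCCCNc1ncnc2c1ncn2[C@@H]1O[C@H](COP(=O)(O)OP(=O)(O)OP(=O)(O)O)[C@@H](O)[C@H]1O`: 47%
Compound 2 `O=C(CI)NCCCCCCC(=O)NCCCCCCNc1ncnc2c1ncn2[C@@H]1O[C@H](COP(=O)(O)OP(=O)(O)OP(=O)(O)O)[C@@H](O)[C@H]1O`: 0%
Compound 3 `O=C(CI)NCCC(=O)NCCCCCCNc1ncnc2c1ncn2[C@@H]1O[C@H](COP(=O)(O)OP(=O)(O)OP(=O)(O)O)[C@@H](O)[C@H]1O`: 0%

In an assay on isolated protein for inhibition of hexokinase-3 (Rattus norvegicus), with a stated time of 6 h, tested at 10 mM (on this read-out lower numbers stand for less inhibition and higher numbers for more inhibition at the one concentration tested (going by the name of the read-out)), compound 3 is level with compound 2 at the digits shown, the two together the lowest of the three numbers, while compound 1 sits higher (a number 47 percentage points lower from compound 1 to compound 3 (beyond the scatter)). Compound 4 `O=C(CI)NCCCC(=O)NCCCCCCNc1ncnc2c1ncn2[C@@H]1O[C@H](COP(=O)(O)OP(=O)(O)OP(=O)(O)O)[C@@H](O)[C@H]1O` differs from compound 3 by (((iodomethyl)carbonyl)amino)methyl in place of ((iodomethyl)carbonyl)amino on a saturated chain carbon, two bonds along the chain from a carbonyl carbon. Among the measured compounds shown here, the step most like it is the one from compound 2 to compound 3, which changed the same chain by more and gave no change at the digits printed from compound 2 to compound 3 (within the scatter). The step from compound 1 to compound 3 was large but altered the linker in another way. Compound 4 is therefore expected to show a number 5 percentage points higher from compound 3 to compound 4 (within the scatter), and its value in this assay is estimated at 5%, between 0% and 20%.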

Compound 4, a percentage reported as inhibition, at one concentration (the size of the read-out at that concentration, not a potency): 0%
Compound 4: middle estimate off by 5 percentage points, on the high side; the measured number falls inside the stated range.
By their numbers in this assay, from the lowest: compounds 2, 3 and 4 (each within the scatter of the next); then compound 1.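

In this assay, (((iodomethyl)carbonyl)amino)methyl in place of ((iodomethyl)carbonyl)amino gives no change at the digits printed from compound 3 to compound 4 (within the scatter), and the comparison with the longest of these chains gives no change at the digits printed from compound 2 to compound 4 (within the scatter), so this chain reads flat at a third length. Compound 1, whose linker has no inner carbonyl, remains apart, with a number 47 percentage points lower from compound 1 to compound 4 (beyond the scatter). Nothing at hand accounts for this result. The compounds shown leave open whether the inner amide or the overall linker length separates compound 1 from the others. A longer unbroken methylene chain, or a chloroacetyl group in place of iodoacetyl, would remain to be read.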